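A new aryl group on a shared core

This account rests on a few compounds, and the source may have more. Where it says the series, first, only, none or still open, it means among the compounds named here.

Of the compounds shown here, three built on one core have been tested in an assay for inhibition of Indoleamine 2,3-dioxygenase 1 (Homo sapiens), read by fluorescence, with a stated time of 24 h; a lower number here means a stronger inhibitor, a higher number a weaker inhibitor. Compound 1 `NS(=O)(=O)CC(=O)NCCSc1nonc1/C(=N/O)Nc1ccc(F)c(C(F)F)c1` gives 13 nM, compound 2 `NS(=O)(=O)CC(=O)NCCSc1nonc1/C(=N/O)Nc1ccc(F)c(Br)c1` gives 12 nM, and compound 3 `NS(=O)(=O)CC(=O)NCCSc1nonc1/C(=N/O)Nc1cccc(Br)c1` gives 8.1 nM, the lowest number of the three, although its steps from the others, a 1.6-fold lower number from compound 1 to compound 3 (0.21 log units; within the scatter) and a 1.5-fold lower number from compound 2 to compound 3 (0.17 log units; within the scatter), lie within the scatter, as does a 1.1-fold lower number from compound 1 to compound 2 (0.03 log units; within the scatter). Compound 4 `N#Cc1cc(N/C(=N\O)c2nonc2SCCNC(=O)CS(N)(=O)=O)ccc1F` carries 3-cyano-4-fluorophenyl in place of 3-bromophenyl on an amine nitrogen. Among the measured compounds shown here, no measured step introduces a nitrile, so the three steps bear on this change only indirectly: each shows that altering the substituents on this ring left this assay unmoved beyond the scatter. Compound 4 is therefore expected to change little, the estimated step being a 1.2-fold higher number from compound 3 to compound 4 (0.09 log units; within the scatter). The estimated value of compound 4 is 10 nM, within a range from 4 nM to 25 nM.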

Compound 4, half-maximal inhibitory concentration: 39 nM
Compound 4: middle estimate off by 3.9-fold (0.59 log units), on the low side, outside the stated range (above it).
By their numbers in this assay, from the lowest: compounds 3, 2 and 1 (each within the scatter of the next); then compound 4.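

Among the compounds shown here, a step of a 3.3-fold higher number from compound 2 to compound 4 (0.51 log units; beyond the scatter) follows cyano in place of bromo, and one of a 3.0-fold higher number from compound 1 to compound 4 (0.48 log units; beyond the scatter) follows cyano in place of difluoromethyl, so the nitrile is the first group at this place to move the number in this assay beyond the scatter. The whole exchange of 3-bromophenyl for 3-cyano-4-fluorophenyl on the amine nitrogen comes with a step of a 4.8-fold higher number from compound 3 to compound 4 (0.68 log units; beyond the scatter) and is the largest of the three. Nothing measured here accounts for this rise.

The compounds shown leave open whether 3-cyanophenyl, without the fluoro, would sit with compound 4 or with compound 3. They also leave open where a methoxy group or a primary carboxamide at this place would fall.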